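Ester for chloro on the aryl ring: antiproliferative notes

The source may report more compounds than this note shows. Statements on the series, on what has been measured and on what is new or still open speak of the compounds shown alone.

Going by the values given here, compound 2 `NS(=O)(=O)NCC1CCN(c2cc(-c3ccc(Cl)cc3)ncn2)CC1` gives 50300 nM in a functional assay on M21 cells (Homo sapiens) for antiproliferative activity, read by sulforhodamine B assay, with a stated time of 48 h (a higher number here means a weaker inhibitor of growth, a lower number a stronger inhibitor of growth), the highest of the two numbers measured so far. Its nearest neighbour is compound 1 `CC(C)(C)c1ccc(-c2cc(N3CCC(CNS(N)(=O)=O)CC3)ncn2)cc1`, which in this assay gives 19300 nM. Among the compounds with values here, the one step between measured compounds is a 2.6-fold higher number from compound 1 to compound 2 (0.42 log units; beyond the scatter), a modest move that lies beyond the scatter.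

Compound 3 `COC(=O)c1ccc(-c2cc(N3CCC(CNS(N)(=O)=O)CC3)ncn2)cc1` has not yet been measured. It differs from compound 2 by methoxycarbonyl in place of chloro on an aromatic carbon. Within the data shown here, no measured step bears directly on this change. Among the measured compounds shown here, the only comparison available, a 2.6-fold higher number from compound 1 to compound 2 (0.42 log units; beyond the scatter), exchanges two other groups at the same aromatic carbon, neither of them the methoxycarbonyl group, and that step was modest. For the measured compounds named here, both measured numbers sit within a narrow band, and the new group has no precedent, so the expected step is a 1.1-fold lower number from compound 2 to compound 3 (0.05 log units; within the scatter), small and of uncertain direction. Compound 3 is therefore expected to give about 45000 nM in this assay, with a range from 12000 nM to 150000 nM. The upper end of that range reflects that compound 2 already stands at 50300 nM.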

Compound 3, concentration for 50% growth inhibition: 14100 nM
For compound 3 the middle estimate is 3.2-fold (0.50 log units) above the measured one; the range from low to high includes it.
By their numbers in this assay, from the lowest: compounds 3 and 1 (each within the scatter of the next); then compound 2.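

At the aromatic carbon para to a large group, the change from chloro to methoxycarbonyl gives a 3.6-fold lower number from compound 2 to compound 3 (0.55 log units; beyond the scatter) in this assay, so this position responds to a group other than tert-butyl, and the size of the move is comparable to that of the earlier step between tert-butyl and chloro. The comparison a 1.4-fold lower number from compound 1 to compound 3 (0.14 log units; within the scatter) places the methoxycarbonyl and tert-butyl compounds together, which leaves compound 2 as the only one set apart, with steps to both others beyond the scatter. The data shown offer no measurement that explains why chloro stands apart here or why two differently built groups read alike.

The compounds shown leave open whether a carboxylic acid, a primary amide or a nitrile at this carbon would read with compound 1 and compound 3 or with compound 2. Going by these compounds alone, with only three groups compared at one carbon and the rest of the structure held constant, no trend can yet be tied to heavy-atom count or to hydrogen-bond acceptors.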